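Methylation of the phenolic hydroxyl across two cores

A few compounds are considered here, and "the series" means these few. Any claim that something is new, unique, unknown or untested is made for them only; others in the source may bear on it.

Compound 1 `O=C(/C=C\Nc1ccc(O)cc1)c1cn(-c2ccccc2)nc1-c1ccccc1` is tested in an ADME assay on HaCaT cells (Homo sapiens) for antiproliferative activity, read by MTT assay, with a stated time of 48 h (on this read-out lower numbers stand for stronger inhibition and higher numbers for weaker inhibition), where compound 1 gives 44600 nM. Compound 2 `COc1ccc(N/C=C\C(=O)c2cn(-c3ccccc3)nc2-c2ccccc2)cc1` carries methyl in place of hydrogen on an oxygen on an aromatic ring. In this assay compound 2 reaches only the limit of > 50000 nM, not a number. The step of an at least 1.1-fold higher number from compound 1 to compound 2 (0.04 log units; that floor lies within the scatter) therefore has a floor only, because of the limit of > 50000 nM in this assay, at which 1 of the 3 values shown sits. Compound 3 `COc1cc(-c2nn(-c3ccccc3)cc2C(=O)/C=C\Nc2ccc(O)cc2)cc(OC)c1OC` sits on a different core; the difference between the two cores is not broken down here. In this assay compound 3 gives 17600 nM, the lower of the two numbers measured. Compound 4 `COc1ccc(N/C=C\C(=O)c2cn(-c3ccccc3)nc2-c2cc(OC)c(OC)c(OC)c2)cc1` carries the same change against compound 3, (methyl in place of hydrogen on an oxygen on an aromatic ring), at a place described in the same words. Among the measured compounds shown here, since the one measured instance of this change gave a higher number with only a floor known, a weaker value is expected for compound 4, a step of a 2.0-fold higher number from compound 3 to compound 4 (0.30 log units; within the scatter). The estimate for compound 4 is 35000 nM, between 18000 nM and 80000 nM.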

Compound 4, half-maximal inhibitory concentration: > 50000 nM
Compound 4: only a limit was reported; the forecaster's own chance of this, stated with the estimate: 30%; middle value at least 1.4-fold (0.15 log units) from the limit.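

In this assay compound 4 reaches only the limit of > 50000 nM and not a number. The change from hydroxy to methoxy on the core of compound 3 therefore has only a floor, an at least 2.8-fold higher number from compound 3 to compound 4 (0.45 log units; beyond the scatter), yet that floor already lies beyond the scatter, whereas the floor on the core of compound 1 does not. The data show a weakening on one core but do not show that the size of the change carries over between cores: the same change on two cores in this assay, an at least 1.1-fold higher number (0.04 log units; that floor lies within the scatter) from compound 1 to compound 2 and an at least 2.8-fold higher number (0.45 log units; beyond the scatter) from compound 3 to compound 4; the limit leaves it open whether they differ.

The step from compound 2 to compound 4 cannot be read, as both values are limits. Open, as far as these compounds go, is how an ethoxy group or an amine in place of the hydroxy would read on either core.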